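Fluorophenyl Swap on a Triazole Sulfonamide: Expected Cytotoxicity

This account rests on a few compounds, and the source may have more. Where it says the series, first, only, none or still open, it means among the compounds named here.

Compound 1 `Cc1ccc(-n2cc(-c3ccccc3NS(=O)(=O)c3c[nH]c(=O)[nH]c3=O)nn2)cc1`: 32400 nM
Compound 2 `O=c1[nH]cc(S(=O)(=O)Nc2ccccc2-c2cn(-c3ccccc3F)nn2)c(=O)[nH]1`: > 100000 nM (a limit)
Compound 3 `Cc1ccc(-n2cc(-c3cccc(NS(=O)(=O)c4c[nH]c(=O)[nH]c4=O)c3)nn2)cc1`: 15800 nM

Of the compounds shown here, three have been tested in an ADME assay on GES1 cells (Homo sapiens) for cytotoxicity, read by MTT assay, with a stated time of 24 h; on this read-out lower numbers stand for higher toxicity in this test and higher numbers for lower toxicity in this test. In this assay compound 1 gives 32400 nM and compound 3 gives 15800 nM. For compound 2 this assay reports only a limit, > 100000 nM. Compound 1 and compound 2 differ by 2-fluorophenyl in place of 4-methylphenyl on an aromatic nitrogen, and this change gave an at least 3.0-fold higher number from compound 1 to compound 2 (0.48 log units; beyond the scatter), reaching (the limit of > 100000 nM in this assay, at which 1 of the 3 values shown sits). The difference between the core of compound 1 and the core of compound 3 is not broken down here. Compound 4 `O=c1[nH]cc(S(=O)(=O)Nc2cccc(-c3cn(-c4ccccc4F)nn3)c2)c(=O)[nH]1` has not been measured; it differs from compound 3 by 2-fluorophenyl in place of 4-methylphenyl on an aromatic nitrogen, the same change at the same place. Since the measured pair showed an at least 3.0-fold higher number from compound 1 to compound 2 (0.48 log units; beyond the scatter), a comparable step is expected, a 3.5-fold higher number from compound 3 to compound 4 (0.54 log units; beyond the scatter). Compound 4 is estimated at 55000 nM in this assay, with a real chance that only a limit is returned.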

Compound 4, half-maximal cytotoxic concentration: "not toxic" (no number reported)
The entry for compound 4 holds no number; there is nothing to compare the estimate with.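

In this assay, for the compounds shown here, compound 4 is reported only as "not toxic", without a number, so no step from compound 3 to compound 4 can be read. The compounds shown leave open how large the change from 4-methylphenyl to 2-fluorophenyl is on either core.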